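The source may hold more compounds than are shown below. What is called first, only, known or untested is meant among the compounds shown, and "the series" means these compounds.

In a functional assay on HepG2 cells (Homo sapiens) for inhibition, read by MTT assay, with a stated time of 48 h (on this read-out lower numbers stand for stronger inhibition and higher numbers for weaker inhibition), two compounds built on the same core have been measured so far. Compound 1 `COc1cc(-c2nccn3cc(-c4ccc5[nH]ccc5c4)nc23)cc(OC)c1OC`, which carries a 1H-indol-5-yl group, gives 146 nM. Compound 2 `COc1cc(-c2nccn3cc(-c4ccc(C(F)(F)F)cc4)nc23)cc(OC)c1OC` has 4-(trifluoromethyl)phenyl in place of 1H-indol-5-yl, and it gives 2630 nM, the higher of the two numbers and so the weaker inhibition.

Compound 3 `COc1cc(-c2nccn3cc(-c4ccc(N)cc4)nc23)cc(OC)c1OC` has not yet been measured. It differs from compound 2 in a single place: amino in place of trifluoromethyl on an aromatic carbon. Seen one bond further out, 4-(trifluoromethyl)phenyl becomes 4-aminophenyl.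

For the measured compounds named here, only one measured step bears on this change: an 18-fold higher number from compound 1 to compound 2 (1.26 log units; beyond the scatter). That large step shows that swapping this group can move the number a long way, but it is a different swap, so it offers only a rough guide. The new compound keeps the phenyl ring and loses the trifluoromethyl group of the weaker compound. A moderate move toward a lower number is therefore expected, a 4.4-fold lower number from compound 2 to compound 3 (0.64 log units; beyond the scatter), smaller than the measured step. For compound 3 the estimated value is 600 nM, with an expected range from 150 nM to 2400 nM.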

Compound 3, half-maximal inhibitory concentration: 252 nM
Compound 3: middle estimate off by 2.4-fold (0.38 log units), on the high side; low and high end bracket the measured number.
By their numbers in this assay, from the lowest: compounds 1 and 3 (each within the scatter of the next); then compound 2.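

In this assay, changing a single group on the phenyl ring is enough to produce a large shift: amino in place of trifluoromethyl on the same aromatic carbon gives a 10-fold lower number from compound 2 to compound 3 (1.02 log units; beyond the scatter). The phenyl ring therefore does not by itself bring the weak result of compound 2, as the earlier comparison with the 1H-indol-5-yl group could not show, and swapping 1H-indol-5-yl for 4-aminophenyl gives a 1.7-fold higher number from compound 1 to compound 3 (0.24 log units; within the scatter), which leaves those two compounds indistinguishable on this read-out. No measurement available here explains why amino and trifluoromethyl differ so much at this carbon.

The compounds shown leave open whether this result is specific to amino or would also hold for other small groups at this carbon, such as a hydroxyl, a methoxy or an acetamide. They also leave open what would happen with the amino group on a different carbon of the ring, or with the phenyl ring replaced by another ring carrying an amine.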